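The source may report more compounds than this note shows. Statements on the series, on what has been measured and on what is new or still open speak of the compounds shown alone.

Measured compounds:
- Compound 1 `Cc1ccc(N2CCN(S(=O)(=O)c3ccc4c(c3)CC(=O)N4)CC2)cc1`: "not active" (no number reported)
- Compound 2 `N#Cc1ccc(N2CCN(S(=O)(=O)c3ccc4c(c3)CC(=O)N4)CC2)cc1`: 3260 nM

Compound 1 and compound 2 share one core and differ only in the group at the far end of the phenyl ring. In an assay on isolated protein for inhibition of lysosomal alpha-glucosidase (Homo sapiens), read by fluorescence, with stated times of 5 min and 45 min (on this read-out lower numbers stand for stronger inhibition and higher numbers for weaker inhibition), compound 1 is reported as "not active" (no number reported), so no number stands for it, while compound 2 gives 3260 nM in this assay, a weak but measurable inhibition. Going by the values given here, with only these two values there is no way to say how large the move from one to the other is; the two values show only that a polar group at that position can bring the compound into the measurable range.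

Compound 3 `O=C1Cc2cc(S(=O)(=O)N3CCN(c4ccc(CO)cc4)CC3)ccc2N1` is the compound to be measured next. It arises from compound 1 by the change (hydroxy in place of hydrogen on a saturated chain carbon bound to an aromatic carbon). This adds a group that can both give and take a hydrogen bond where compound 1 has none. Among the compounds with values here, since compound 1 has no number, no step can be computed; the expectation is only that compound 3 may reach the weak, measurable range seen for compound 2, or may again fall below it. Compound 3 is therefore estimated at 8000 nM in this assay, with a range from 2000 nM to 30000 nM.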

Compound 3, half-maximal inhibitory concentration: 13000 nM
Beside the measured number, compound 3's estimate is 1.6-fold (0.21 log units) below it; measured number inside the range.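

In this assay, going by these compounds alone, compound 1 gives "not active" (no number reported) and so its step to compound 3 cannot be read, yet compound 3 does carry a number, which shows that cyano is not the only group on this aromatic carbon that can reach the measurable range. The two groups that give numbers are not equivalent: hydroxymethyl in place of cyano brings a 4.0-fold higher number from compound 2 to compound 3 (0.60 log units; beyond the scatter) and this modest loss of inhibition lies beyond the usual scatter of repeated measurements, leaving cyano the better of the two. No measurement shown here gives a reason for this difference.

Still open, on these data alone, is how other groups at this place would compare, such as an aminomethyl group, a carboxylic acid or a longer chain ending in hydroxy. Also open is whether cyano would keep its lead over hydroxymethyl on a different core, since all three compounds shown share the same one.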